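A few compounds are considered here, and "the series" means these few. Any claim that something is new, unique, unknown or untested is made for them only; others in the source may bear on it.

Compound 3 `Clc1ccnc2cc(OCc3ccccc3)ccc12` gives 5170 nM in a functional assay on SK-OV-3 cells (Homo sapiens) for cytotoxicity, read by MTT assay, with a stated time of 48 h (on this read-out higher numbers stand for weaker inhibition and lower numbers for stronger inhibition), the highest of the three numbers recorded, though nothing separates it beyond the scatter: compound 1 `CCCCOc1ccc2c(Cl)ccnc2c1` gives 4130 nM, compound 2 `CCCCCCCCOc1ccc2c(Cl)ccnc2c1` gives 4300 nM, and the steps of a 1.0-fold higher number from compound 1 to compound 2 (0.02 log units; within the scatter) and a 1.3-fold higher number from compound 1 to compound 3 (0.10 log units; within the scatter) both stay within the scatter. Compound 4 `CCOc1ccc2c(Cl)ccnc2c1` differs from compound 3 by methyl in place of phenyl on a saturated chain carbon bound to an oxygen on an aromatic ring, on a saturated chain carbon bound to an oxygen on an aromatic ring. Within the data shown here, the one step that bears on this place, swapping phenyl for propyl, is a 1.3-fold higher number from compound 1 to compound 3 (0.10 log units; within the scatter), and lengthening the chain further, a 1.0-fold higher number from compound 1 to compound 2 (0.02 log units; within the scatter), moved the number no more. Compound 4 is therefore expected to sit near compound 3, with an estimated step of a 1.1-fold lower number from compound 3 to compound 4 (0.06 log units; within the scatter) in this assay. The estimate for compound 4 is 4500 nM, between 2200 nM and 9500 nM.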

Compound 4, half-maximal inhibitory concentration: 3460 nM
For compound 4 the middle estimate is 1.3-fold (0.11 log units) above the measured one, and the stated range covers the measured number.
By their numbers in this assay, from the lowest: compounds 4, 1, 2 and 3 (each within the scatter of the next).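

In this assay, methyl in place of phenyl on a saturated chain carbon bound to an oxygen on an aromatic ring gives a 1.5-fold lower number from compound 3 to compound 4 (0.17 log units; within the scatter), so losing this aromatic ring does not separate the two compounds. Shortening the chain gives a 1.2-fold lower number from compound 2 to compound 4 (0.09 log units; within the scatter) and a 1.2-fold lower number from compound 1 to compound 4 (0.08 log units; within the scatter), so all the chains shown here, from the shortest to the longest, remain within the scatter of one another. Nothing measured here offers an explanation for these numbers.

From the compounds shown here alone, whether an amine or a carboxylic acid on this chain would move the number beyond the scatter remains open.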